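This account rests on a few compounds, and the source may have more. Where it says the series, first, only, none or still open, it means among the compounds named here.

Compound 1 `CCN(Cc1cccnc1)c1ccc(C(=O)N2CCc3ccc(OS(N)(=O)=O)cc3C2)cc1` is the stronger of the two compounds measured in an assay on HEK293 cells for inhibition of Steryl-sulfatase (Homo sapiens), tested at 0.1 uM (on this read-out lower numbers stand for a weaker effect and higher numbers for a stronger effect at the one concentration tested), where compound 1 gives 35.7%. Compound 2 `NS(=O)(=O)Oc1ccc2c(c1)CN(C(=O)c1cccc(N3CCN(Cc4ccccc4)CC3)c1)CC2` gives 0% in this assay, a gap beyond the usual scatter, so compound 1 stands highest of the two. Compound 3 `CCN(Cc1ccccc1)c1ccc(C(=O)N2CCc3ccc(OS(N)(=O)=O)cc3C2)cc1` has not yet been measured; it differs from compound 1 in a single place: phenyl in place of pyridin-3-yl on a saturated chain carbon bound to a nitrogen on an aromatic ring. Among the compounds with values here, no comparable step between measured compounds is known, so the effect of this change is uncertain. The step of a number 0.7 percentage points lower from compound 1 to compound 3 (within the scatter) is expected to lie within the usual scatter, in no clear direction. Compound 3 is therefore estimated at 35%, between 15% and 55%.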

Compound 3, a percentage reported as inhibition, at one concentration (the size of the read-out at that concentration, not a potency): 66.9%
Compound 3: the middle estimate sits 31.9 percentage points below what was measured; the measured number lies above the stated range.
By their numbers in this assay, from the lowest: compound 2; then compound 1; then compound 3.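

In this assay, phenyl in place of pyridin-3-yl gives a number 31.2 percentage points higher from compound 1 to compound 3 (beyond the scatter). Within the data shown here, this position is therefore sensitive to the ring it carries: swapping one ring nitrogen for carbon, with the heavy-atom count unchanged, is enough to produce a large step, something the earlier compounds could not show. Nothing available explains this step. The compounds shown leave open what pyridin-4-yl, 4-fluorophenyl or cyclohexyl would give at this place. They also leave open whether a longer chain could replace the ethyl group.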